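Fluoro in Place of Methyl: Expected Cytotoxicity

A few compounds are considered here, and "the series" means these few. Any claim that something is new, unique, unknown or untested is made for them only; others in the source may bear on it.

Compound 1, `Cc1cccc(Oc2cccc(CN3CCC(n4cc(C)c(=O)[nH]c4=O)CC3)c2)c1`, was tested in an ADME assay on MRC5 cells (Homo sapiens) for cytotoxicity, read by fluorescence and resazurin assay, with a stated time of 3 days; on this read-out higher numbers stand for weaker inhibition and lower numbers for stronger inhibition. In this assay compound 1 gives > 64000 nM, which is a limit of the assay and not a measured number. Compound 2, `Cc1cn(C2CCN(Cc3cc(Oc4ccccc4)ccn3)CC2)c(=O)[nH]c1=O`, belongs to the same set. In this assay compound 2 gives > 64000 nM, again a limit rather than a number. Compound 3, `Cc1cn(C2CCN(Cc3cc(Oc4cc(Cl)cc(Cl)c4)ccn3)CC2)c(=O)[nH]c1=O`, in this assay gives "not determined" (no result reported), so no result is reported for it. Compound 1 therefore stands nowhere in particular: the only other number shown is the limit of > 64000 nM in this assay, at which 2 of the 3 values shown sit, and the third entry is empty.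

Compound 4, `Cc1cn(C2CCN(Cc3cccc(Oc4cccc(F)c4)c3)CC2)c(=O)[nH]c1=O`, differs from compound 1 in one place: fluoro in place of methyl on an aromatic carbon. Going by the values given here, no measured pair in this set differs in just one place, so there is no comparable step to lean on. With only two limits to go on, this fluoro in place of methyl on an aromatic carbon is expected to make no difference beyond the scatter, a number no higher from compound 1 to compound 4 (the limit leaves the size open). For compound 4 the estimated value is 64000 nM, within a range from 30000 nM to 200000 nM, and the most likely outcome is that the assay again reports only a limit rather than a number.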

Compound 4, half-maximal inhibitory concentration: > 64000 nM
Compound 4 was reported as a limit (the forecaster's own chance of this, stated with the estimate: 85%); the middle value lies on the limit itself.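

In this assay compound 4 gives > 64000 nM, which is a limit of the assay and not a number. Compound 1 also stands at a limit, so the step from compound 1 to compound 4, fluoro in place of methyl, cannot be read: the limit of > 64000 nM in this assay, at which 3 of the 4 values shown sit. The compounds shown leave open at what concentration, if any, either compound would become cytotoxic.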